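The compounds below may be only part of what the source reports. "The series", "measured", "known", "first", "only" and "open" are said of these compounds alone.

Measured compounds in an assay on FRT-Jurkat cells for inhibition of nuclear factor NF-kappa-B complex (Homo sapiens), read by flow cytometry, with a stated time of 24 h, tested at 10 uM; on this read-out lower numbers stand for less inhibition and higher numbers for more inhibition at the one concentration tested (going by the name of the read-out):
- compound 1 `Cc1ccccc1Nc1cccc2c1C(=O)N(C1CCC(=O)NC1=O)C2=O`: 7%
- compound 2 `Cc1ccc(Nc2ccc3c(c2)C(=O)N(C2CCC(=O)NC2=O)C3=O)cc1`: 5%
- compound 3 `CCCCCc1ccc(Nc2ccc3c(c2)C(=O)N(C2CCC(=O)NC2=O)C3=O)cc1`: 12%

All three numbers are small, and compound 1 sits second highest of the three; its gap to compound 2 and its gap to compound 3 are both within the scatter, so no order among them can be claimed. Compound 4 `CC(C)c1ccc(Nc2cccc3c2C(=O)N(C2CCC(=O)NC2=O)C3=O)cc1` differs from compound 1 by 4-isopropylphenyl in place of 2-methylphenyl on a nitrogen on an aromatic ring. Among the measured compounds shown here, the only measured step, a number 7 percentage points higher from compound 2 to compound 3 (within the scatter), also enlarges the alkyl part of the phenyl ring and stayed within the scatter. Nothing measured here suggests a change beyond the scatter, so compound 4 is expected to give 9% (range 0% to 20%), an estimated step of a number 2 percentage points higher from compound 1 to compound 4 (within the scatter).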

Compound 4, a percentage reported as inhibition, at one concentration (the size of the read-out at that concentration, not a potency): 19%
Compound 4: the middle estimate sits 10 percentage points below what was measured; low and high end bracket the measured number.
By their numbers in this assay, from the lowest: compounds 2, 1, 3 and 4 (each within the scatter of the next, the first and the last beyond it).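

In this assay, among the compounds shown here, the change from 2-methylphenyl to 4-isopropylphenyl on a nitrogen on an aromatic ring gives a number 12 percentage points higher from compound 1 to compound 4 (beyond the scatter) and is the first step here to pass the scatter. This shows that the group at this position can shift the read-out, though only modestly. No available evidence accounts for this step.

The swap alters both the alkyl group and its place on the phenyl ring, so the two contributions cannot be separated. On these data alone, how an amine or a carboxylic acid on that phenyl ring would read also remains open.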